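The compounds below may be only part of what the source reports. "The series", "measured", "known", "first", "only" and "open" are said of these compounds alone.

Measured compounds:
compound 1 `C[Si](C)(C)C#Cc1c[nH]c(=O)[nH]c1=O` — 268000 nM
compound 2 `O=c1[nH]c(=O)n([C@@H]2O[C@H](CO)[C@@H](O)[C@H]2O)cc1C#CC(O)c1ccccc1` — 34200 nM

In an ADME assay on A549 cells (Homo sapiens) for cytotoxicity, read by MTT assay (a lower number here means that less compound is tolerated, a higher number that more compound is tolerated), compound 1 gives 268000 nM, the highest of the two numbers shown; the nearest is compound 2, whose 34200 nM lies beyond the scatter below it. Compound 3 `CCC#Cc1c[nH]c(=O)[nH]c1=O` differs from compound 1 in one place: a group of 2 heavy atoms (2 carbon; no ring) in place of a group of 4 heavy atoms (3 carbon, 1 silicon; no ring), on a triple-bonded carbon. For the measured compounds named here, no step between two measured compounds shows what such a change does to this read-out, so the expectation rests on compound 1 alone. The expected change is small, at most a modest drop: a 1.2-fold lower number from compound 1 to compound 3 (0.07 log units; within the scatter). Compound 3 is therefore estimated at 230000 nM, within 90000 nM to 600000 nM.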

Compound 3, half-maximal cytotoxic concentration: 253000 nM
Compound 3: the middle estimate sits 1.1-fold (0.04 log units) below what was measured; measured number inside the range.
By their numbers in this assay, from the lowest: compound 2; then compounds 3 and 1 (each within the scatter of the next).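

In this assay, ethyl in place of the group of 4 heavy atoms, on a triple-bonded carbon, gives a 1.1-fold lower number from compound 1 to compound 3 (0.03 log units; within the scatter) and so leaves the number within the scatter. Silicon is therefore not required at this position to keep the number where it stands on the shared core. No available evidence bears on why this is so.

On these data alone, what an amine, a carboxylic acid or a longer chain would do on this triple-bonded carbon remains open. Compound 2 differs from compound 1 and compound 3 in more than one place, so what sets its number apart also stays unresolved.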